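The compounds below may be only part of what the source reports. "The series", "measured", "known", "first", "only" and "open" are said of these compounds alone.

Compound 1: `COc1ccccc1N1CCN(CCCNc2c(C(C)=O)c(-c3ccccc3)nn(C)c2=O)CC1` — 20.3 nM
Compound 2: `CC(=O)c1c(-c2ccccc2)nn(C)c(=O)c1NCCN1CCN(c2ccccc2F)CC1` — 3.77 nM

Both compounds share one core and were tested in an assay on isolated protein for binding affinity to Alpha-1B adrenergic receptor (Homo sapiens), read by radioligand binding; on this read-out lower numbers stand for stronger inhibition and higher numbers for weaker inhibition. Compound 2 gives 3.77 nM, the lowest of the two numbers, while compound 1 gives the higher number 20.3 nM, a gap wider than the usual scatter of this assay. For the measured compounds named here, no pair of measured compounds differs in a single place, so no measured step is available to lean on.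

Compound 3 is `CC(=O)c1c(-c2ccccc2)nn(C)c(=O)c1NCCN1CCN(c2ccccc2Cl)CC1`, not yet measured. It differs from compound 2 by one change: chloro in place of fluoro on an aromatic carbon. Going by the values given here, no measured pair shows what this change does, so the expectation rests on compound 2 alone. The step expected here, a 1.1-fold higher number from compound 2 to compound 3 (0.03 log units; within the scatter), is small, in no firm direction, and not beyond the scatter. Compound 3 is therefore estimated to give 4 nM, within a range from 1.5 nM to 12 nM.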

Compound 3, inhibition constant: 0.75 nM
For compound 3 the middle estimate is 5.3-fold (0.73 log units) above the measured one, and the stated range ends above it.
By their numbers in this assay, from the lowest: compound 3; then compound 2; then compound 1.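

Swapping fluoro for chloro on an aromatic carbon ortho to a large group gives, in this assay, a 5.0-fold lower number from compound 2 to compound 3 (0.70 log units; beyond the scatter) and so provides the one single-place comparison among these compounds. It shows that this position on the ring is sensitive: exchanging one heavy atom for another, with the counted hydrogen-bond donors, acceptors and net charge unchanged, is enough to move the number clearly. Nothing shown here bears on the reason for this step.

The compounds shown leave open how bromo, methyl or trifluoromethyl would fare at this same place on the ring. They also leave open whether a chloro group would bring a similar step on the chain and ring of compound 1, which differs from compound 2 in more than one place.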